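A few compounds are considered here, and "the series" means these few. Any claim that something is new, unique, unknown or untested is made for them only; others in the source may bear on it.

Compound 1 `CO[C@]1(c2cc(F)cc(S(=O)(=O)c3ccc(/C(C)=N/OCC#N)cc3)c2)CCO[C@@H](C)C1` gives 60 nM; compound 2 `C/C(=N\OC(=O)C(C)(C)C)c1ccc(Sc2cc(F)cc(C3CCOCC3)c2)cc1` gives 40 nM; compound 3 `CO[C@]1(c2cnc(S(=O)(=O)c3ccc(/C(C)=N/OCC#N)cc3)s2)CCO[C@@H](C)C1` gives 140 nM.

In a functional assay (blood) for inhibition, with Homo sapiens as the target (a higher number here means a weaker inhibitor, a lower number a stronger inhibitor), compound 2 holds the lowest number of the three. Compound 1 lies within the scatter of it, so the two cannot be ranked; compound 3 lies beyond the scatter, at a higher number. Compound 4 `C/C(=N\O)c1ccc(Sc2cc(F)cc(C3CCOCC3)c2)cc1` has not yet been measured in this assay. It keeps everything of compound 2 except one point: hydrogen in place of (tert-butyl)carbonyl on an oxygen — read one bond further out, a hydroxy replaces the ((tert-butyl)carbonyl)oxy. Going by the values given here, no measured pair shows this change, so there is no step to lean on. From the change a step of a 1.3-fold lower number from compound 2 to compound 4 (0.12 log units; within the scatter) is expected, small enough to stay within the scatter and, if anything, toward a lower number. Compound 4 is estimated at 30 nM, within 10 nM to 100 nM.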

Compound 4, half-maximal inhibitory concentration: 80 nM
The estimate for compound 4 lay 2.7-fold (0.43 log units) below the measured number, within the range that was stated.
By their numbers in this assay, from the lowest: compounds 2, 1, 4 and 3 (each within the scatter of the next, the first and the last beyond it).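

On the oxygen bonded to the double-bonded nitrogen, hydrogen in place of (tert-butyl)carbonyl gives a 2.0-fold higher number from compound 2 to compound 4 (0.30 log units; within the scatter) in this assay. The 6 heavy atoms of that group can therefore be removed without a difference that can be told from the usual scatter, so compound 2 and compound 4 cannot be ranked. Nothing at hand explains this result.

As far as these compounds go, a methyl or a longer chain ending in an amine on this oxygen remains untested here. Also open, from the compounds shown here alone, is whether a hydroxy would read the same on the core of compound 1.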